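The source may report more compounds than this note shows. Statements on the series, on what has been measured and on what is new or still open speak of the compounds shown alone.

In a functional assay on EKVX cells (Homo sapiens) for cytotoxicity, read by sulforhodamine B assay, with a stated time of 48 h (a lower number here means a stronger inhibitor of growth, a higher number a weaker inhibitor of growth), the three measured compounds gave:

compound 1, `Nc1nc(Cl)c2ncn(Cc3ccc(CCl)cc3)c2n1`: 7240 nM
compound 2, `ClCc1cccc(Cn2cnc3c(Cl)nc(Cl)nc32)c1`: 2310 nM
compound 3, `ClCc1ccc(Cn2cnc3c(Cl)nc(Cl)nc32)cc1`: 31600 nM

Compound 3 and compound 1 share one core and differ in a single place, (amino in place of chloro on an aromatic carbon). That single change produced a 4.4-fold lower number from compound 3 to compound 1 (0.64 log units; beyond the scatter), so the amino-bearing compound 1 is the stronger inhibitor of the pair. Compound 2 is built from the same atoms as compound 3 joined differently; the difference between the two cores is not broken down here. Compound 2 gives the lowest number of the three, and its steps to the other two lie beyond the scatter.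

Compound 4, `Nc1nc(Cl)c2ncn(Cc3cccc(CCl)c3)c2n1`, has not yet been measured. It differs from compound 2 by amino in place of chloro on an aromatic carbon, which is the same change, at a place described in the same words, that turned compound 3 into compound 1. If the change acts as it did there, the step is expected to be a 3.3-fold lower number from compound 2 to compound 4 (0.52 log units; beyond the scatter) in this assay, because a 4.4-fold lower number from compound 3 to compound 1 (0.64 log units; beyond the scatter) was seen on the closely related core. Compound 4 is therefore expected to give about 700 nM, most likely between 250 nM and 2000 nM.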

Compound 4, concentration for total growth inhibition: 36300 nM
Estimate against measurement, compound 4: 52-fold (1.71 log units) below; the measured number lies above the stated range.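

In this assay amino in place of chloro gave a 16-fold higher number from compound 2 to compound 4 (1.20 log units; beyond the scatter) and so weakened growth inhibition on this core, whereas the same change strengthened it on the core of compound 3. The result does not show why the direction reverses, and two pairs are too few to predict what the change would do on any further core. What it does show is that a step seen on one core in this series cannot be assumed to carry over to a closely related one, even when the change is described in the same words, and the two steps clearly differ: the same change on two cores in this assay, a 4.4-fold lower number (0.64 log units; beyond the scatter) from compound 3 to compound 1 and a 16-fold higher number (1.20 log units; beyond the scatter) from compound 2 to compound 4, 69-fold (1.84 log units) apart, beyond the scatter of two such steps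

The compounds shown leave open whether a different group at that same place, such as methylamino, methoxy or a plain hydrogen, would behave more like the amino group of compound 1 or that of compound 4. They also leave open whether the reversal would persist if the chloromethyl group gave way to a hydroxymethyl or a methyl group.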